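Amino for 1-hydroxyethyl: an expectation for compound 3

A few compounds are considered here, and "the series" means these few. Any claim that something is new, unique, unknown or untested is made for them only; others in the source may bear on it.

Compound 1 `CC(Nc1ccccc1Oc1ccccc1)=C1C(=O)CC(c2ccccc2)CC1=O` gives 79 nM
Compound 2 `CC(Nc1ccccc1Oc1ccc(C(C)O)cc1)=C1C(=O)CC(c2ccccc2)CC1=O` gives 75 nM

Within the data shown here, these two numbers are all that a functional assay on HeLa cells (Homo sapiens) for antiproliferative activity, read by cell counting, with a stated time of 3 days (on this read-out higher numbers stand for weaker inhibition and lower numbers for stronger inhibition), has yielded for the series so far. Among the measured compounds shown here, the one measured step is a 1.1-fold lower number from compound 1 to compound 2 (0.02 log units; within the scatter) and so compound 2 stands level with compound 1, with no order between them.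

Compound 3 `CC(Nc1ccccc1Oc1ccc(N)cc1)=C1C(=O)CC(c2ccccc2)CC1=O` has not yet been measured. It differs from compound 2 at one place amino in place of 1-hydroxyethyl on an aromatic carbon with amino in place of 1-hydroxyethyl on an aromatic carbon, para to a large group.

For the measured compounds named here, only one measured step bears on this change. It put 1-hydroxyethyl at that same place in compound 2 and came out as a 1.1-fold lower number from compound 1 to compound 2 (0.02 log units; within the scatter) without moving the number beyond the scatter. Going by the values given here, no measured compound carries amino, so the evidence is indirect and thin. In this assay the expected result is a 1.1-fold higher number from compound 2 to compound 3 (0.03 log units; within the scatter) with no step beyond the scatter anticipated in either direction. For compound 3 the estimated value is 80 nM with an expected range from 30 nM to 210 nM.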

Compound 3, half-maximal inhibitory concentration: 39 nM
Compound 3: the middle estimate sits 2.1-fold (0.31 log units) above what was measured, and the stated range covers the measured number.
By their numbers in this assay, from the lowest: compounds 3, 2 and 1 (each within the scatter of the next, the first and the last beyond it).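

In this assay, among these compounds, the amino group gives the first step that clears the scatter (a 2.0-fold lower number from compound 1 to compound 3 (0.31 log units; beyond the scatter)). That step is modest, but it shows that a group on this aromatic carbon, para to a large group, can move the number, which the 1-hydroxyethyl of compound 2 had not shown. The direct exchange of 1-hydroxyethyl for amino stays within the scatter (a 1.9-fold lower number from compound 2 to compound 3 (0.28 log units; within the scatter)), so compound 2 and compound 3 stand without an order between them, and only compound 3 is set apart from compound 1, which has hydrogen at this place; no measurement at hand bears on what lies behind this difference.

The compounds shown leave open whether the step belongs to amino in particular or would also come with a hydroxyl, a methoxy group or a carboxylic acid on the same carbon. They also leave open whether an N-methylamino, a dimethylamino or an acetamido group would keep the number of compound 3, and whether any of these would carry it further beyond the scatter.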